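Thiophene in place of pyridine on the biaryl carbon

This account rests on a few compounds, and the source may have more. Where it says the series, first, only, none or still open, it means among the compounds named here.

Compound 1 `COc1cc(CC(O)c2ccc(-c3ccccc3[N+](=O)[O-])cc2)c([N+](=O)[O-])cc1OC` gives 9500 nM in an ADME assay on HeLa Rh cells (Homo sapiens) for cytotoxicity, read by microscopy; a lower number here means that less compound is tolerated, a higher number that more compound is tolerated. Compound 2 `COc1cc(CC(O)c2ccc(-c3cccnc3)cc2)c([N+](=O)[O-])cc1OC` gives > 263000 nM in this assay, which is a limit of the assay rather than a number, as marked in the limit of > 263000 nM in this assay, at which 1 of the 2 values shown sits. Among the measured compounds shown here, the only measured step, an at least 27-fold higher number from compound 1 to compound 2 (1.44 log units; beyond the scatter), is large and runs toward greater tolerance. Compound 3 `COc1cc(CC(O)c2ccc(-c3cccs3)cc2)c([N+](=O)[O-])cc1OC` differs from compound 2 by thiophen-2-yl in place of pyridin-3-yl on an aromatic carbon. For the measured compounds named here, no measured step covers this exact change; the step from compound 1 shows only that the group at this carbon shifts the read-out strongly. A partial move back toward compound 1 is expected: compound 3 is estimated at 60000 nM, with a range from 12000 nM to 263000 nM. The expected step is an at least 4.3-fold lower number from compound 2 to compound 3 (0.64 log units; beyond the scatter).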

Compound 3, half-maximal cytotoxic concentration: 11000 nM
Beside the measured number, compound 3's estimate is 5.5-fold (0.74 log units) above it, outside the stated range (below it).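

In this assay, the high tolerance seen with pyridin-3-yl does not extend to thiophen-2-yl, another aromatic ring with one hetero atom, giving an at least 23-fold lower number from compound 2 to compound 3 (1.37 log units; beyond the scatter). Thiophen-2-yl and 2-nitrophenyl cannot be told apart here, with a 1.2-fold higher number from compound 1 to compound 3 (0.06 log units; within the scatter), so pyridin-3-yl alone stands apart among the three groups. The value of compound 2 remains a limit of the assay and not a number: the limit of > 263000 nM in this assay, at which 1 of the 3 values shown sits.

As far as these compounds go, it remains open whether this separation depends on the ring nitrogen of pyridin-3-yl or on that nitrogen's place in the ring. Unsubstituted phenyl, pyridin-2-yl and pyridin-4-yl on this carbon would separate these readings.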